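Working notes: from compound 2 to compound 3

This account rests on a few compounds, and the source may have more. Where it says the series, first, only, none or still open, it means among the compounds named here.

Series measured in a functional assay on MDA-MB-231 cells (Homo sapiens) for antiproliferative activity, read by MTT assay, with a stated time of 72 h; a lower number here means a stronger inhibitor of growth, a higher number a weaker inhibitor of growth:
- compound 1 `Cc1c(C(=O)Nc2ccc(SC#N)cc2)nnn1-c1ccc(C(C)C)cc1`: > 100000 nM (a limit)
- compound 2 `Cc1ccc(-n2nnc(C(=O)Nc3ccc(SC#N)cc3)c2C)cc1C`: > 100000 nM (a limit)
- compound 3 `Cc1ccc(Cl)cc1-n1nnc(C(=O)Nc2ccc(SC#N)cc2)c1C`: not yet measured

Compound 2 stands only at a limit, > 100000 nM.

The next change keeps the shared core and alters the aryl group on the aromatic nitrogen: 5-chloro-2-methylphenyl in place of 3,4-dimethylphenyl on an aromatic nitrogen. Here 5-chloro-2-methylphenyl takes the place of 3,4-dimethylphenyl, on the aromatic nitrogen next to the ring atom that bears a methyl group.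

Within the data shown here, one measured step bears on this, and it concerns the same nitrogen: a step that the two limits leave unreadable from compound 1 to compound 2. Its size cannot be read, so it offers no guide to the size or direction of a change. The remaining evidence is the limit of > 100000 nM in this assay, at which 2 of the 2 values shown sit. On that basis, no step beyond the scatter is expected in this assay, although a limit on compound 2 leaves room for an undetected change.

The expected step is a number no higher from compound 2 to compound 3 (the limit leaves the size open). The estimate for compound 3 is 100000 nM, with an expected range from 20000 nM to 200000 nM.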

Compound 3, concentration for 50% growth inhibition: 44600 nM
Compound 3: the middle estimate sits 2.2-fold (0.35 log units) above what was measured; the measured number falls inside the stated range.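

In this assay, the group on the aromatic nitrogen proves able to move the read-out: 5-chloro-2-methylphenyl gives an at least 2.2-fold lower number from compound 2 to compound 3 (0.35 log units; beyond the scatter), and the same group gives an at least 2.2-fold lower number from compound 1 to compound 3 (0.35 log units; beyond the scatter). Going by these compounds, both steps start from a limit, so their full size stays open, and the earlier step between the two aryl groups at the limit cannot be read. Compound 3 is the only compound shown that carries a number rather than a limit, so this position is not silent in this series, although the evidence for it rests on this single compound and the remaining values are limits: the limit of > 100000 nM in this assay, at which 2 of the 3 values shown sit.

5-chloro-2-methylphenyl differs from 3,4-dimethylphenyl in more than one substituent, so the compounds shown do not separate the contribution of the chlorine from that of the placement of the methyl group. Also open, on these data alone, is how an amine or a carboxylic acid on this aryl ring would read in this assay, and whether a further change at this nitrogen would bring the number lower than that of compound 3.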